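This account rests on a few compounds, and the source may have more. Where it says the series, first, only, none or still open, it means among the compounds named here.

Working notes on the acetyl-bearing series. Compound 1 `COc1ccc(-c2cc(C(C)=O)c3[nH]c(-c4ccc(OC)cc4)cc3c2)cc1` carries two 4-methoxyphenyl groups on the shared core; in a functional assay on MCF7 cells (Homo sapiens) for cytotoxicity, read by MTT assay, with a stated time of 2 days (on this read-out lower numbers stand for higher toxicity in this test and higher numbers for lower toxicity in this test), compound 1 gives 25200 nM. Compound 2 `CC(=O)c1cc(/C=C/c2ccc(F)cc2)cc2cc(-c3ccccc3)[nH]c12` carries a styryl group bearing fluorine and an unsubstituted phenyl; in this assay compound 2 gives 18500 nM. Compound 3 `CC(=O)c1cc(/C=C/c2ccc(F)cc2)cc2cc(-c3ccc(F)cc3)[nH]c12` adds fluoro on that phenyl. In this assay compound 3 gives only a limit of the assay, > 100000 nM. Among the compounds with values here, the sole measured step at this position, an at least 5.4-fold higher number from compound 2 to compound 3 (0.73 log units; beyond the scatter), therefore places compound 3 at the boundary marked by the limit of > 100000 nM in this assay, at which 1 of the 3 values shown sits, and its true number is not pinned down.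

Compound 4 `COc1ccc(-c2cc3cc(/C=C/c4ccc(F)cc4)cc(C(C)=O)c3[nH]2)cc1` is not yet measured. It differs from compound 3 by methoxy in place of fluoro on an aromatic carbon. Two things bear on this step: the upward movement on going from hydrogen to fluoro just described, and the fact that compound 1, which carries the methoxy-bearing phenyl, sits at 25200 nM, well inside the measurable range. Replacing fluoro by methoxy is thus expected to bring the number back down into that range, a step of an at least 3.3-fold lower number from compound 3 to compound 4 (0.52 log units; beyond the scatter). Compound 4 is estimated at 30000 nM in this assay, with a likely range from 10000 nM to 100000 nM, pending measurement.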

Compound 4, concentration lethal to 50% of the cells: 83000 nM
The estimate for compound 4 lay 2.8-fold (0.44 log units) below the measured number; measured number inside the range.
By their numbers in this assay, from the lowest: compounds 2 and 1 (each within the scatter of the next); then compound 4. At a limit, above all of these: compound 3.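

In this assay, methoxy in place of hydrogen on this phenyl gives a step with a firm size, a 4.5-fold higher number from compound 2 to compound 4 (0.65 log units; beyond the scatter), so a rise in the number on substituting the hydrogen is no longer tied to fluoro alone, and the rise with methoxy is a measured one; a second change elsewhere on the shared core also counts, with 2-(4-fluorophenyl)ethenyl in place of 4-methoxyphenyl giving a 3.3-fold higher number from compound 1 to compound 4 (0.52 log units; beyond the scatter), so the methoxy-bearing phenyl does not set the number by itself. Methoxy against fluoro stays unresolved, since the step reads only as an at least 1.2-fold lower number from compound 3 to compound 4 (0.08 log units; that floor lies within the scatter), and that floor does not establish any real difference between the two groups. Compound 3 is held only by a limit of the assay, not by a number: the limit of > 100000 nM in this assay, at which 1 of the 4 values shown sits.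

Going by these compounds, whether an amine or a carboxylic acid on this phenyl would also raise the number, or would lower it, remains open. Also open, on these data alone, is how far compound 3 truly lies from compound 4, and so whether fluoro and methoxy differ at this position at all.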